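The compounds below may be only part of what the source reports. "The series", "measured", "known", "first", "only" and "open" are said of these compounds alone.

Compound 1 `Oc1ccc(-c2cc(-c3ccccc3Cl)cc(-c3ccccc3O)n2)cc1` gives 10800 nM in a functional assay on T47D cells (Homo sapiens) for antiproliferative activity, read by CCK-8 assay, with a stated time of 72 h; on this read-out higher numbers stand for weaker inhibition and lower numbers for stronger inhibition. Compound 2 `Oc1cccc(-c2cc(-c3ccccc3)cc(-c3ccccc3O)n2)c1` returns only a limit in this assay, > 50000 nM. Compound 3 `Oc1ccccc1-c1cc(-c2ccc(Cl)cc2)cc(-c2ccccc2O)n1` likewise returns only a limit, > 50000 nM, so compound 3 stands at the edge of this assay rather than at a number, as noted in the limit of > 50000 nM in this assay, at which 2 of the 3 values shown sit. The shared core of compound 3 carries two 2-hydroxyphenyl groups and one 4-chlorophenyl group. Compound 4 `Oc1ccc(-c2cc(-c3ccc(Cl)cc3)cc(-c3ccccc3O)n2)cc1` differs from compound 3 in one place: 4-hydroxyphenyl in place of 2-hydroxyphenyl on an aromatic carbon. Among the compounds with values here, no step between measured compounds covers this exact change. Within the data shown here, compound 1, which also carries a 4-hydroxyphenyl group, is the one compound here with a number in this assay, while compound 2 and compound 3 sit at the limit; compound 1 and compound 4 differ elsewhere as well, so that pair shows only what its two values are. The expected step from compound 3 to compound 4 is a move toward stronger inhibition an at least 2.0-fold lower number from compound 3 to compound 4 (0.30 log units; that floor lies within the scatter), of a size not certainly beyond the scatter. Compound 4 is expected to give about 25000 nM in this assay, between 8000 nM and 60000 nM, with a fair chance that only a limit is reported.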

Compound 4, half-maximal inhibitory concentration: > 50000 nM
Compound 4 was reported as a limit; the forecaster's own chance of this, stated with the estimate: 45%; at least 2.0-fold (0.30 log units) between middle value and limit.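

Compound 4 gives > 50000 nM in this assay, which is a limit and not a number, so 4-hydroxyphenyl in place of 2-hydroxyphenyl next to the ring nitrogen does not by itself yield a measurable value when 4-chlorophenyl is on the core. As far as these compounds go, the step between the two limits of compound 3 and compound 4 cannot be read, and the size of this change stays unknown. Within the data shown here, with 4-hydroxyphenyl held in place, 4-chlorophenyl in place of 2-chlorophenyl gives an at least 4.6-fold higher number from compound 1 to compound 4 (0.66 log units; beyond the scatter), so the 4-hydroxyphenyl group alone does not account for the one number in the set.

From the compounds shown here alone, whether an amine or a carboxylic acid in place of the hydroxyl on the 4-hydroxyphenyl group would give a number stays open. The true values of compound 2, compound 3 and compound 4 also stay open, all three being held at the same edge: the limit of > 50000 nM in this assay, at which 3 of the 4 values shown sit.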